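The source may hold more compounds than are shown below. What is called first, only, known or untested is meant among the compounds shown, and "the series" means these compounds.

Working notes on the series. Compound 1 `Cc1ccc(OCC(=O)N(C)Cc2cccs2)cc1` in an assay on HEK293 cells for agonist activity at transient receptor potential cation channel subfamily M member 8 (Homo sapiens), read by fluorescence and calcium flux, with a stated time of 15 min (a higher number here means that more compound is needed for the effect, a lower number that less compound is needed), gives 400 nM, the lowest of the two numbers in hand. Compound 2 `CCN(Cc1nccs1)C(=O)COc1ccc(C)cc1` in this assay gives 3060 nM; compound 2 differs from compound 1 in more than one place, so its weaker number is noted without further reading. Compound 3 `COCCN(Cc1cccs1)C(=O)COc1ccc(C)cc1` is not yet measured in this assay. It differs from compound 1 by methoxymethyl in place of hydrogen on a saturated chain carbon bound to an amide-type nitrogen. Going by the values given here, no single-point step is known here, so the expectation for compound 3 rests on the change itself: a modest loss, a step of a 2.3-fold higher number from compound 1 to compound 3 (0.35 log units; beyond the scatter) is expected, barely beyond the scatter. Compound 3 is estimated at 900 nM, within 300 nM to 3000 nM.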

Compound 3, half-maximal effective concentration: 400 nM
Compound 3: the middle estimate sits 2.3-fold (0.35 log units) above what was measured; the range from low to high includes it.
By their numbers in this assay, from the lowest: compounds 1 and 3 (each within the scatter of the next); then compound 2.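

In this assay, going by these compounds alone, the change of methyl to 2-methoxyethyl gives no change at the digits printed from compound 1 to compound 3 (within the scatter) and is the first step that can be read in one place. The saturated chain carbon bound to an amide-type nitrogen thus takes methoxymethyl in place of hydrogen with the number held, which compound 2 could not show. Nothing measured bears on why the number holds. 

Open, as far as these compounds go, is whether a plain propyl chain, an amine or a carboxylic acid at this place would also keep the number. From the compounds shown here alone, how much longer the chain can grow here also remains open.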